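The source may report more compounds than this note shows. Statements on the series, on what has been measured and on what is new or still open speak of the compounds shown alone.

In an ADME assay on MT4 cells (Homo sapiens) for cytotoxicity, read by MTT assay, with a stated time of 4 days (a lower number here means that less compound is tolerated, a higher number that more compound is tolerated), compound 1 `Cc1ccc(-c2c(C)c(-c3ccccc3)c(C(OC(C)(C)C)C(=O)O)c(C)c2NS(C)(=O)=O)cc1C` gives > 50000 nM, which is a limit of the assay and not a number. Compound 2 `Cc1ccc(-c2c(C)c(-c3ccc(C)c(C)c3)c(C(OC(C)(C)C)C(=O)O)c(C)c2NS(=O)(=O)C2CC2)cc1C` gives a true number in this assay, 11000 nM. Compound 3 `Cc1ccc(-c2c(C)c(-c3ccc(Cl)cc3)c(C(OC(C)(C)C)C(=O)O)c(C)c2NS(C)(=O)=O)cc1C` departs from compound 1 in one place, phenyl to 4-chlorophenyl, with chloro in place of hydrogen on an aromatic carbon. Within the data shown here, no measured step covers this change, so only a modest move toward less tolerated compound is expected. The expected step is an at least 1.2-fold lower number from compound 1 to compound 3 (0.09 log units; that floor lies within the scatter). For compound 3, the estimated value is 40000 nM, within an expected range of 15000 nM to 60000 nM.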

Compound 3, half-maximal cytotoxic concentration: 26000 nM
Beside the measured number, compound 3's estimate is 1.5-fold (0.19 log units) above it; the range from low to high includes it.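

In this assay, among these compounds, the change from phenyl to 4-chlorophenyl gives the only comparison here between compounds that differ in one place. Compound 1 gives > 50000 nM, which is a limit of the assay and not a number. The change can therefore be read only as an at least 1.9-fold lower number from compound 1 to compound 3 (0.28 log units; that floor lies within the scatter), and its full size stays unknown because the starting value is not a true number: the limit of > 50000 nM in this assay, at which 1 of the 3 values shown sits.

From the compounds shown here alone, whether a fluoro or methoxy group in place of chloro would give a similar number remains open. So does whether chloro would have a similar effect on the other aromatic ring.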